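A few compounds are considered here, and "the series" means these few. Any claim that something is new, unique, unknown or untested is made for them only; others in the source may bear on it.

Of the compounds shown here, three of one series have so far been measured in a functional assay on MGC-803 cells (Homo sapiens) for inhibition, read by MTT assay, with a stated time of 72 h; a higher number here means a weaker inhibitor, a lower number a stronger inhibitor. Compound 1, `CCCCCc1c(C)nc2nc(SCc3ccc(Cl)cc3)nn2c1Nc1cc(-c2ccccc2)[nH]n1`, gives 7140 nM. Compound 2, `Cc1cc(Nc2cc(-c3ccccc3)[nH]n2)n2nc(SCc3ccccc3Br)nc2n1`, gives 3650 nM. Compound 3, `Cc1cc(Nc2ccn(Cc3csc4ccc(Cl)cc34)n2)n2nc(SCc3ccc(Br)cc3)nc2n1`, gives 1570 nM. Among these three numbers compound 2 holds the second highest; its value and that of compound 1 lie within the scatter of each other, so nothing can be said of their order, whereas compound 3 gives a number that is lower by more than the scatter. For the measured compounds named here, no two of the measured compounds differ from one another in a single place, so no measured step is available to guide the next comparison.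

Compound 4, `CCCSc1nc2nc(C)cc(Nc3cc(-c4ccccc4)[nH]n3)n2n1`, has not yet been measured in this assay. It differs from compound 2 in one place: ethyl in place of 2-bromophenyl on a saturated chain carbon bound to a sulfur. Every measured compound carries a ring-bearing group on that sulfur, and none shows what a plain chain does there, so the size of the step is open and can only be guessed from the spread of the three values. In this assay compound 4 is expected to give around 6500 nM, with a range from 2200 nM to 20000 nM. The step this implies is expected to be a 1.8-fold higher number from compound 2 to compound 4 (0.25 log units; within the scatter), a shift toward a weaker inhibitor that may well not exceed the scatter.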

Compound 4, half-maximal inhibitory concentration: 12600 nM
Compound 4: the middle estimate sits 1.9-fold (0.29 log units) below what was measured; measured number inside the range.
By their numbers in this assay, from the lowest: compound 3; then compounds 2, 1 and 4 (each within the scatter of the next, the first and the last beyond it).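

In this assay, ethyl in place of 2-bromophenyl on a saturated chain carbon bound to a sulfur gives a 3.5-fold higher number from compound 2 to compound 4 (0.54 log units; beyond the scatter). For the compounds shown here, this is the first comparison that changes one place only, and it shows that this position is not indifferent to what it carries: the step lies beyond the scatter, though it is modest in size, and it runs toward a weaker inhibitor when 2-bromobenzyl gives way to propyl. Nothing among the data shown accounts for the step.

On these data alone, whether the step follows the loss of the ring or the loss of the bromine stays open, and a plain benzyl on the sulfur would separate the two. Also open, as far as these compounds go, is how a longer chain such as hexyl, or a chain carrying an amine or a carboxylic acid, would compare with propyl in this place, and whether the same step would hold on the cores of compound 1 or compound 3.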